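Swapping the aryl group on the triazole in a spiro series

The compounds below may be only part of what the source reports. "The series", "measured", "known", "first", "only" and "open" are said of these compounds alone.

Compound 1 `N#CC1=C(N)Oc2c(c3nc4ccccc4nc3c3ccccc23)C12C(=O)N(Cc1cnnn1-c1cccc(Br)c1)c1ccccc12` in a functional assay on HCT-116 cells (Homo sapiens) for antiproliferative activity, read by MTT assay, with a stated time of 48 h (on this read-out higher numbers stand for weaker inhibition and lower numbers for stronger inhibition), gives > 50000 nM, which is a limit of the assay.
Compound 2 `COc1ccc(-n2nncc2CN2C(=O)C3(C(C#N)=C(N)Oc4c3c3nc5ccccc5nc3c3ccccc43)c3ccccc32)cc1` in this assay gives > 50000 nM, also a limit of the assay.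
Compound 3 `N#CC1=C(N)Oc2c(N)cc3nc4ccccc4nc3c2C12C(=O)N(Cc1cnnn1-c1cccc(C(F)(F)F)c1)c1ccccc12` in this assay gives 18900 nM.

Compound 3 thus holds the only number shown; the two other values are limits, as the limit of > 50000 nM in this assay, at which 2 of the 3 values shown sit, sums up. From compound 3 to compound 4 `N#CC1=C(N)Oc2c(N)cc3nc4ccccc4nc3c2C12C(=O)N(Cc1cnnn1-c1ccc(F)c(Cl)c1)c1ccccc12` the change is 3-chloro-4-fluorophenyl in place of 3-(trifluoromethyl)phenyl on an aromatic nitrogen. Among the compounds with values here, the one measured step at this same place, a step that the two limits leave unreadable from compound 1 to compound 2, runs between two limits and so has no readable size; no measured step bears on the change with a known size. The expectation is therefore a step of a 1.1-fold higher number from compound 3 to compound 4 (0.02 log units; within the scatter) in this assay, within the scatter. Compound 4 is expected to give 20000 nM in this assay, between 7000 nM and 60000 nM.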

Compound 4, half-maximal inhibitory concentration: > 50000 nM
Compound 4 ended at the assay's limit; the forecaster's own chance of this, stated with the estimate: 35%; at least 2.5-fold (0.39 log units) between middle value and limit.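

In this assay, putting 3-chloro-4-fluorophenyl in place of 3-(trifluoromethyl)phenyl on this aromatic nitrogen gives an at least 2.6-fold higher number from compound 3 to compound 4 (0.42 log units; beyond the scatter). Within the data shown here, this is the first readable sign that the aryl group at this position matters, as the step from compound 1 to compound 2 cannot be read. Compound 4 sits at a limit of the assay, so the full size of the step stays unknown: the limit of > 50000 nM in this assay, at which 3 of the 4 values shown sit.

The compounds shown leave open whether an unsubstituted phenyl, or a phenyl carrying an amine or a carboxylic acid, would match compound 3 at 18900 nM.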